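Removal of the ring methyl in a weak alkyne series

The source may hold more compounds than are shown below. What is called first, only, known or untested is meant among the compounds shown, and "the series" means these compounds.

Compound 2 `Cc1cccc(C#Cc2cnc(C(C)(C)C)nc2)c1` has no number in an assay on HEK293 cells for positive allosteric modulation of metabotropic glutamate receptor 5 (Rattus norvegicus); a higher number here means that more compound is needed for the effect, a lower number that less compound is needed; it is recorded as "not active" (no number reported). Compound 1 `CCc1ncc(C#Cc2cccc(C)c2)cn1` is likewise recorded in this assay as "not active" (no number reported), so two of the three measured entries carry no value. Only compound 3 `CNc1ncc(C#Cc2cccc(C)c2)cn1` gives a number, and in this assay compound 3 gives 21100 nM. Compound 4 `CC(C)(C)c1ncc(C#Cc2ccccc2)cn1` differs from compound 2 by hydrogen in place of methyl on an aromatic carbon. Within the data shown here, no measured pair in this set shows what a hydrogen in place of a methyl on an aromatic carbon does here, and compound 2 itself is without a number, so the expected size of the step in this assay cannot be taken from the data. Compound 4 is expected to give 30000 nM, within 8000 nM to 100000 nM, with a substantial chance that only a limit is reported.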

Compound 4, half-maximal effective concentration: 247000 nM
Beside the measured number, compound 4's estimate is 8.2-fold (0.92 log units) below it; measured number above the stated range.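

Among these compounds, compound 2 carries no number, so no step from it to compound 4 can be read. As far as these compounds go, what hydrogen in place of methyl on an aromatic carbon does stays open. Nothing at hand accounts for the value of compound 4.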